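Exchanging One Substituted Phenyl for Another

The compounds below may be only part of what the source reports. "The series", "measured", "known", "first", "only" and "open" are said of these compounds alone.

Three compounds share a core and differ only in the group on an amine nitrogen in a ring. Compound 1 `Nc1scc(CN2CCN(c3cccc4ccccc34)CC2)c1C(=O)c1ccc(Cl)cc1` carries a naphthalen-1-yl there; in a functional assay on CHO cells with adenosine receptor A1 (Homo sapiens) as the target, read by cAMP accumulation and immunoassay, with a stated time of 6 min, tested at 1 uM (a lower number here means a stronger effect, a higher number a weaker effect of the compound at the concentration tested), compound 1 gives 2.9%. Compound 2 `Nc1scc(CN2CCN(c3c(F)cc(F)cc3F)CC2)c1C(=O)c1ccc(Cl)cc1` carries a 2,4,6-trifluorophenyl, and in this assay compound 2 gives -56%. Compound 3 `Nc1scc(CN2CCN(c3ccc(F)c(Cl)c3)CC2)c1C(=O)c1ccc(Cl)cc1` carries a 3-chloro-4-fluorophenyl, and in this assay compound 3 gives -60%. Compound 3 thus has the lowest of the three numbers: its nearest neighbour is compound 2, with a number 4 percentage points lower from compound 2 to compound 3 (within the scatter), which lies within the scatter, while its furthest is compound 1, with a number 62.9 percentage points lower from compound 1 to compound 3 (beyond the scatter).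

Compound 4 `Nc1scc(CN2CCN(c3ccccc3Cl)CC2)c1C(=O)c1ccc(Cl)cc1` is not yet measured. It differs from compound 3 in one place: 2-chlorophenyl in place of 3-chloro-4-fluorophenyl on an amine nitrogen in a ring. Two kinds of measured step bear on this. The move from naphthalen-1-yl to a substituted phenyl was large, a number 58.9 percentage points lower from compound 1 to compound 2 (beyond the scatter) and a number 62.9 percentage points lower from compound 1 to compound 3 (beyond the scatter), whereas the move between two substituted phenyls, a number 4 percentage points lower from compound 2 to compound 3 (within the scatter), stayed within the scatter. With compound 4 again carrying a substituted phenyl on that nitrogen, the expected step is a number 5 percentage points higher from compound 3 to compound 4 (within the scatter), nothing beyond the scatter. Compound 4 is estimated to give -55% in this assay, with a range from -78% to -25%.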

Compound 4, a percentage reported as activity, at one concentration (the size of the read-out at that concentration, not a potency): -5.2%
Compound 4: the middle estimate sits 49.8 percentage points below what was measured, and the stated range ends below it.
By their numbers in this assay, from the lowest: compounds 3 and 2 (each within the scatter of the next); then compounds 4 and 1 (each within the scatter of the next).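

Among the groups on the amine nitrogen in a ring, the earlier pair of substituted phenyls had differed by no more than the scatter, but 2-chlorophenyl breaks that picture in this assay, with a number 54.8 percentage points higher from compound 3 to compound 4 (beyond the scatter) and a number 50.8 percentage points higher from compound 2 to compound 4 (beyond the scatter), so carrying a substituted phenyl at this place does not by itself settle the read-out. With a number 8.1 percentage points lower from compound 1 to compound 4 (within the scatter), 2-chlorophenyl cannot be told apart from naphthalen-1-yl here, and the large divide in these four compounds therefore separates compound 2 and compound 3 from compound 1 and compound 4, not naphthalen-1-yl from the substituted phenyls. Nothing available bears on what lies behind this divide.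

The change from 3-chloro-4-fluorophenyl to 2-chlorophenyl removes the fluorine and moves the chlorine at once, and the compounds shown do not separate these two changes. From the compounds shown here alone, whether a 3-chlorophenyl, a 4-fluorophenyl or an unsubstituted phenyl would fall with compound 2 and compound 3 or with compound 1 and compound 4 remains open.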